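A few compounds are considered here, and "the series" means these few. Any claim that something is new, unique, unknown or untested is made for them only; others in the source may bear on it.

Working notes on the series. Compound 1 `O=C(Nc1ccc2nc(NC(=O)C3CCCCC3)sc2c1)c1ccc(Cl)cc1Cl` pairs a cyclohexanecarbonyl amide with a dichlorobenzoyl amide on the shared core. In a functional assay on WI-38 VA13 cells (Homo sapiens) for cytotoxicity (on this read-out lower numbers stand for an effect already at smaller amounts and higher numbers for an effect only at larger amounts of compound), compound 1 gives only a limit, > 4 ug/mL, one of the values sitting at the cut-off described by the limit of > 4 ug/mL in this assay, at which 1 of the 3 values shown sits. Compound 2 `C=CCOC(=O)Nc1ccc2nc(NC(=O)C3CCCCC3)sc2c1` carries allyloxy in place of 2,4-dichlorophenyl on a carbonyl carbon, and in this assay compound 2 gives 0.58 ug/mL. That single change is an at least 6.8-fold lower number from compound 1 to compound 2 (0.83 log units; beyond the scatter). Compound 3 `CC(=O)Nc1nc2ccc(NC(=O)c3c(Cl)cccc3Cl)cc2s1` combines an acetamido group with a dichlorobenzamide, and in this assay compound 3 gives 0.6 ug/mL. Among the two real numbers it is the higher one, but its nearest neighbour compound 2 lies within the scatter, so no order between compound 3 and compound 2 can be read.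

Compound 4 `CCCOC(=O)Nc1nc2ccc(NC(=O)c3c(Cl)cccc3Cl)cc2s1` differs from compound 3 by propoxy in place of methyl on a carbonyl carbon. Within the data shown here, the only measured step that touches a carbonyl carbon is an at least 6.8-fold lower number from compound 1 to compound 2 (0.83 log units; beyond the scatter), where an alkoxy group entering at such a carbon went with a lower number; the present change again brings an alkoxy group to a carbonyl carbon, though in place of methyl and on the other acyl group, so it bears only loosely. A modest lowering, or no step beyond the scatter, is expected as a 1.5-fold lower number from compound 3 to compound 4 (0.18 log units; within the scatter). Compound 4 is expected to give 0.4 ug/mL. For compound 4 the likely range is estimated from 0.15 ug/mL to 1.2 ug/mL.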

Compound 4, half-maximal effective concentration: 0.0025 ug/mL
The estimate for compound 4 lay 160-fold (2.20 log units) above the measured number, and the stated range ends above it.
By their numbers in this assay, from the lowest: compound 4; then compounds 2 and 3 (each within the scatter of the next). At a limit, above all of these: compound 1.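

On the carbonyl carbon whose other neighbour is the amide-type nitrogen, the change from acetamido to (propoxycarbonyl)amino is anything but neutral in this assay: a 240-fold lower number from compound 3 to compound 4 (2.38 log units; beyond the scatter). The earlier step that brought an alkoxy group to a carbonyl carbon, an at least 6.8-fold lower number from compound 1 to compound 2 (0.83 log units; beyond the scatter), starts from a limit and replaces 2,4-dichlorophenyl on the other acyl group, whereas this step has a real number at both ends and replaces only methyl, so its full size can be read. The one limit on record for this assay has no bearing on this step, and nothing measured here gives a cause for its size.

Still open, as far as these compounds go, is whether the step depends on the propoxy chain itself or holds for alkoxy groups at this carbonyl carbon in general, a question that methoxy or a longer chain such as butoxy or hexyloxy would address. Also open, from the compounds shown here alone, is whether an amine at the same carbon, giving a urea, would sit with compound 3 or with compound 4 in this assay.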